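The source may hold more compounds than are shown below. What is called first, only, known or untested is meant among the compounds shown, and "the series" means these compounds.

Measured in a physicochemical assay for lipophilicity, at pH 7.4; a lower number here means a more polar compound, a higher number a more lipophilic compound:
- compound 1 `Cc1cc(C)c(CN2CCc3c(Cl)cc(-c4cn[nH]c4)c(Cl)c3C2=O)c(=O)[nH]1`: 3
- compound 2 `Cc1cc(C)c(CN2CCc3c(Cl)cc(-c4c(C)noc4C)c(Cl)c3C2=O)c(=O)[nH]1`: 3.1

Among the compounds with values here, compound 2 is not separated from compound 1, the only other compound measured so far: a number 0.10 log units higher from compound 1 to compound 2 (within the scatter).

Compound 3 `Cc1cc(C)c(CN2CCc3c(Cl)cc(-c4cn[nH]c4C)c(Cl)c3C2=O)c(=O)[nH]1` has not yet been measured. The change leading to it is 5-methyl-1H-pyrazol-4-yl in place of 3,5-dimethyl-1,2-oxazol-4-yl on an aromatic carbon. Here 5-methyl-1H-pyrazol-4-yl replaces 3,5-dimethyl-1,2-oxazol-4-yl on an aromatic carbon, ortho to a chloro group. Within the data shown here, the one measured step that bears on this exchange is the step already given, made at the same place and between the 3,5-dimethyl-1,2-oxazol-4-yl and 1H-pyrazol-4-yl groups. Among the measured compounds shown here, no measured step isolates the methyl group on the pyrazolyl ring. No change beyond the scatter is therefore expected in this assay, and the estimated step is no change at the digits printed from compound 2 to compound 3 (within the scatter). For compound 3 the expected value is 3.1, with an estimated range of 2.7 to 3.5.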

Compound 3, distribution coefficient: 3.1
Beside the measured number, compound 3's estimate shows no gap at the digits printed, within the range that was stated.
By their numbers in this assay, from the lowest: compounds 1, 2 and 3 (each within the scatter of the next).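

In this assay the exchange of 3,5-dimethyl-1,2-oxazol-4-yl for 5-methyl-1H-pyrazol-4-yl gives no change at the digits printed from compound 2 to compound 3 (within the scatter) and so adds a second step at this aromatic carbon, ortho to a chloro group, that stays within the scatter. Within the data shown here, the methyl group on the pyrazolyl ring can now be read on its own: methyl in place of hydrogen gives a number 0.10 log units higher from compound 1 to compound 3 (within the scatter) and the earlier compounds offered no such pair. Nothing available explains why these steps stay within the scatter.

Still open, going by these compounds, is whether a carboxylic acid, an amine or a longer chain on this aromatic carbon would give a step beyond the scatter in this assay. Also open, on these data alone, is what the chloro group ortho to this carbon contributes, as all three compounds carry it.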